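A few compounds are considered here, and "the series" means these few. Any claim that something is new, unique, unknown or untested is made for them only; others in the source may bear on it.

Compound 1 `Cc1nn(C2COC2)cc1Nc1nc(N)c2c(C#N)c(N3CCC[C@H]3C)n(C)c2n1` is one of two compounds that share a core and have been tested in an assay on HEK293 cells for inhibition of Leucine-rich repeat serine/threonine-protein kinase 2 (Homo sapiens), with a stated time of 48 h; on this read-out higher numbers stand for weaker inhibition and lower numbers for stronger inhibition; in this assay compound 1 gives 240 nM. Compound 2 `Cc1c(Nc2nc(N)c3c(C#N)c(N4CCC[C@H]4C)n(C)c3n2)cnn1CC1(O)COC1`, which carries a different group on its five-membered ring, gives 220 nM in this assay, and the two numbers lie within the usual scatter of each other, so compound 1 stands together with compound 2 rather than apart from it. Compound 3 `Cc1nn(C)cc1Nc1nc(N)c2c(C#N)c(N3CCC[C@H]3C)n(C)c2n1` has not yet been measured. It differs from compound 1 by methyl in place of oxetan-3-yl on an aromatic nitrogen. For the measured compounds named here, no measured pair shows this change, so the step from compound 1 to compound 3 is estimated as a 1.2-fold lower number from compound 1 to compound 3 (0.08 log units; within the scatter), with no change expected beyond the scatter. Compound 3 is therefore expected to give 200 nM in this assay, in a range from 70 nM to 600 nM.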

Compound 3, half-maximal inhibitory concentration: 190 nM
Compound 3: middle estimate off by 1.1-fold (0.02 log units), on the high side; measured number inside the range.
By their numbers in this assay, from the lowest: compounds 3, 2 and 1 (each within the scatter of the next).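

In this assay the exchange of oxetan-3-yl for methyl gives a 1.3-fold lower number from compound 1 to compound 3 (0.10 log units; within the scatter) on an aromatic nitrogen of the five-membered aromatic ring. For the compounds shown here, this is the first direct reading of this change at this position: the four-membered ring and its hydrogen-bond acceptor can be replaced by a single methyl with no shift beyond the usual scatter. Going by these compounds, whether an amine, a carboxylic acid or a longer chain on this nitrogen would leave the number equally unmoved stays open. No available measurement bears on why this change leaves the number in place.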